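A Thiophene Replaces the Formylphenyl Arm

This account rests on a few compounds, and the source may have more. Where it says the series, first, only, none or still open, it means among the compounds named here.

Of the compounds shown here, three sharing one core have been tested in a functional assay on NCI-H522 cells (Homo sapiens) for inhibition, read by sulforhodamine B assay, with a stated time of 48 h, tested at 10 uM; on this read-out lower numbers stand for less inhibition and higher numbers for more inhibition at the one concentration tested (going by the name of the read-out). Compound 1 `Brc1cn2ccnc2c(-c2ccc3ncn(C4CCCCC4)c3c2)n1` carries a bromo group and gives 16.2%. Compound 2 `c1ccc(-c2cn3ccnc3c(-c3ccc4ncn(C5CCCCC5)c4c3)n2)cc1` carries a phenyl group in that position and gives 58.1%. Compound 3 `O=Cc1ccc(-c2cn3ccnc3c(-c3ccc4ncn(C5CCCCC5)c4c3)n2)cc1` carries a 4-formylphenyl group and gives 25.3%, which places it second highest of the three, close to compound 1 and well apart from compound 2.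

Two steps describe the spread: a number 41.9 percentage points higher from compound 1 to compound 2 (beyond the scatter), and a number 32.8 percentage points lower from compound 2 to compound 3 (beyond the scatter). The third, a number 9.1 percentage points higher from compound 1 to compound 3 (within the scatter), is small.

Compound 4 `c1cn2cc(-c3ccsc3)nc(-c3ccc4ncn(C5CCCCC5)c4c3)c2n1` is not yet measured. It differs from compound 3 as follows: thiophen-3-yl in place of 4-formylphenyl on an aromatic carbon. The entering group is an aromatic ring without the formyl group, so the step that bears most directly is a number 32.8 percentage points lower from compound 2 to compound 3 (beyond the scatter), which shows that adding the formyl group cost a large amount, and a number 41.9 percentage points higher from compound 1 to compound 2 (beyond the scatter), which shows that a plain aromatic ring gave a large gain. An increase beyond the scatter is therefore expected in this assay, estimated as a number 19.7 percentage points higher from compound 3 to compound 4 (beyond the scatter). For compound 4 the expected value is 45%, within a range of 22% to 68%.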

Compound 4, a percentage reported as inhibition, at one concentration (the size of the read-out at that concentration, not a potency): 10.3%
Beside the measured number, compound 4's estimate is 34.7 percentage points above it; measured number below the stated range.
By their numbers in this assay, from the lowest: compounds 4, 1 and 3 (each within the scatter of the next, the first and the last beyond it); then compound 2.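

In this assay, the large value of compound 2 proved not to be a general feature of a plain aromatic ring at this aromatic carbon, since swapping its phenyl for thiophen-3-yl gave a number 47.8 percentage points lower from compound 2 to compound 4 (beyond the scatter) as a large loss. The formyl-bearing ring of compound 3 also stands apart from this new ring, with a number 15 percentage points lower from compound 3 to compound 4 (beyond the scatter) as a modest step, while thiophen-3-yl cannot be told apart from the bromo group, with a number 5.9 percentage points lower from compound 1 to compound 4 (within the scatter) lying within the scatter. Among the four groups shown, only the phenyl of compound 2 is beyond the scatter of all the others, and nothing available explains this difference between the phenyl and thiophen-3-yl groups.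

The compounds shown leave open whether the drop follows the smaller ring or the sulfur atom, a question that a pyridyl or furan-3-yl ring on the same carbon could help to separate. They also leave open whether substituents other than formyl on the phenyl ring, such as an amine or a carboxylic acid, would keep or lose the value of compound 2.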